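Swapping the sulfonamide substituent in an indoleamine dioxygenase series

A few compounds are considered here, and "the series" means these few. Any claim that something is new, unique, unknown or untested is made for them only; others in the source may bear on it.

Compound 1 `O=S1(=O)CC(Nc2nonc2/C(=N/O)Nc2ccc(F)c(Br)c2)C1`: 59 nM
Compound 2 `N=S1(=O)CC(Nc2nonc2/C(=N/O)Nc2ccc(F)c(Br)c2)C1`: 53 nM
Compound 3 `CN(C)S(=O)(=O)CCNc1nonc1/C(=N/O)Nc1ccc(F)c(Br)c1`: 17 nM

In an assay on HeLa cells for inhibition of Indoleamine 2,3-dioxygenase 1 (Homo sapiens), read by spectrophotometry, with a stated time of 24 h (a lower number here means that less compound is needed, a higher number that more compound is needed for the effect), compound 3 gives 17 nM, the lowest of the three numbers. Its advantage over the ring-bearing analogues is modest but real: a 3.5-fold lower number from compound 1 to compound 3 (0.54 log units; beyond the scatter) and a 3.1-fold lower number from compound 2 to compound 3 (0.49 log units; beyond the scatter), while a 1.1-fold lower number from compound 1 to compound 2 (0.05 log units; within the scatter). Compound 4 `O=S(=O)(CCNc1nonc1/C(=N/O)Nc1ccc(F)c(Br)c1)NCC1CC1` keeps the open chain of compound 3 and changes only the far end: (cyclopropylmethyl)amino in place of dimethylamino on a sulfonyl sulfur. Going by the values given here, no measured pair shows this kind of change, so the two earlier steps give only indirect guidance, and they point to the open-chain sulfonyl group being the part that matters. The number for compound 4 is therefore expected to stay close to that of compound 3, with a 1.1-fold lower number from compound 3 to compound 4 (0.05 log units; within the scatter) as the estimate. Compound 4 is expected to give about 15 nM, within 6 nM to 40 nM.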

Compound 4, half-maximal effective concentration: 268 nM
The estimate for compound 4 lay 18-fold (1.25 log units) below the measured number; measured number outside the range, above it.
By their numbers in this assay, from the lowest: compound 3; then compounds 2 and 1 (each within the scatter of the next); then compound 4.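

Within the open-chain compounds, the group on the sulfonyl sulfur matters: in this assay, (cyclopropylmethyl)amino in place of dimethylamino gives a 16-fold higher number from compound 3 to compound 4 (1.20 log units; beyond the scatter). The open chain alone therefore does not secure a low number. No available measurement explains this loss.

From the compounds shown here alone, the change adds a hydrogen-bond donor and a three-membered ring together, so their separate contributions remain open. A methylamino group would carry the donor without the ring, while a morpholine on the sulfonyl sulfur would carry a ring without the donor.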